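The source may hold more compounds than are shown below. What is called first, only, known or untested is meant among the compounds shown, and "the series" means these compounds.

Compound 3 `O=C(O)CNC(=O)CN(c1nc(Cl)nc2[nH]cnc12)C1CC1` gives 9.08% in a functional assay on the whole organism (Tail, strain ICR) with Mus musculus as the target, in the tail flick test, with a stated time of 150 min, at a dose of 25 umol/kg by the oral route; a higher number here means a stronger effect of the compound at the dose given, a lower number a weaker effect. Its number is nominally the highest of the three measured, yet it sits within the scatter of compound 2 `NC(=O)C[C@H](NC(=O)CN(c1nc(Cl)nc2[nH]cnc12)C1CC1)C(=O)O`, which gives 7.51%, and of compound 1 `CC[C@H](C)[C@H](NC(=O)CN(c1nc(Cl)nc2[nH]cnc12)C1CC1)C(=O)O`, which gives 6.71%. The steps among them, a number 0.8 percentage points higher from compound 1 to compound 2 (within the scatter), a number 2.4 percentage points higher from compound 1 to compound 3 (within the scatter) and a number 1.6 percentage points higher from compound 2 to compound 3 (within the scatter), all change the same position, the saturated chain carbon bound to an amide-type nitrogen and a carbonyl carbon, and none of them reaches beyond the scatter. Compound 4 `C[C@@H](O)[C@H](NC(=O)CN(c1nc(Cl)nc2[nH]cnc12)C1CC1)C(=O)O` differs from compound 3 at that very position: 1-hydroxyethyl in place of hydrogen on a saturated chain carbon bound to an amide-type nitrogen and a carbonyl carbon. Three substitutions at this carbon, sec-butyl, carbamoylmethyl and hydrogen, have produced only steps within the scatter, so the entry of 1-hydroxyethyl is expected to behave alike. The step from compound 3 is therefore expected to be small, a number 1.1 percentage points lower from compound 3 to compound 4 (within the scatter). Compound 4 is estimated to give 8% in this assay, with a range from 2% to 16%.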

Compound 4, a percentage reported as activity, at one dose (the size of the read-out at that dose, not a potency): 24%
Estimate against measurement, compound 4: 16 percentage points below, and the stated range ends below it.
By their numbers in this assay, from the lowest: compounds 1, 2 and 3 (each within the scatter of the next); then compound 4.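

In this assay, 1-hydroxyethyl shows that this saturated chain carbon can move the read-out, with a number 14.9 percentage points higher from compound 3 to compound 4 (beyond the scatter) and a number 16.5 percentage points higher from compound 2 to compound 4 (beyond the scatter), whereas sec-butyl, carbamoylmethyl and hydrogen had stayed within the scatter of one another. The closest comparison is a number 17.3 percentage points higher from compound 1 to compound 4 (beyond the scatter), where hydroxy stands in place of ethyl, so a branched chain at this carbon is not enough on its own: compound 1 carries one and stays with compounds 2 and 3, and only compound 4 rises. Nothing available explains why this change raises the effect.

The compounds shown leave open whether a hydroxymethyl or a methoxyethyl group at this carbon would give the same rise, and whether the other arrangement of the 1-hydroxyethyl stereocentre would keep it. They also leave open whether the rise holds at other doses and times.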